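Working notes on cytotoxicity across compounds 1 to 4

The compounds below may be only part of what the source reports. "The series", "measured", "known", "first", "only" and "open" are said of these compounds alone.

Compound 1 `Cc1cc(NC(=O)Nc2ccc(C)c(Cl)c2)c2ccccc2n1` was tested in an ADME assay on Raji cells (Homo sapiens) for cytotoxicity, with a stated time of 72 h; on this read-out higher numbers stand for an effect only at larger amounts of compound and lower numbers for an effect already at smaller amounts. In this assay compound 1 gives > 25000 nM, which is a limit of the assay and not a number. Compound 2 `Cc1cc(NC(=O)Nc2cnc3ccccc3c2)c2ccccc2n1` shares the core of compound 1 with a different aryl partner; in this assay compound 2 gives > 25000 nM, again a limit. Compound 3 `Cc1cc(NC(=O)Nc2ccc(C(=O)O)c(O)c2)c2ccccc2n1` carries an acidic and a hydroxyl substituent on its aryl partner; in this assay compound 3 gives > 25000 nM, also a limit. Going by the values given here, compound 1 therefore stands at the same place as everything else measured so far: the limit of > 25000 nM in this assay, at which 3 of the 3 values shown sit, so no ranking among the three is possible, and no step between measured compounds can be computed.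

Compound 4 `Cc1cc(NC(=O)Nc2cccc(Cl)c2)c2ccccc2n1` is the next member to be tested. Relative to compound 1 the change is hydrogen in place of methyl on an aromatic carbon. Among the compounds with values here, on the evidence of three limits and no measured step, the expected step from compound 1 to compound 4 in this assay is a step that the limit leaves unreadable from compound 1 to compound 4, that is, none beyond the scatter. Compound 4 is accordingly expected to give about 30000 nM in this assay, within a range of 15000 nM to 60000 nM, most likely reported once more as a limit rather than a number.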

Compound 4, half-maximal effective concentration: 18000 nM
Beside the measured number, compound 4's estimate is 1.7-fold (0.22 log units) above it, within the range that was stated.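

In this assay, hydrogen in place of methyl on this aromatic carbon, ortho to a chloro group and para to a large group, gives an at least 1.3-fold lower number from compound 1 to compound 4 (0.14 log units; that floor lies within the scatter). Going by these compounds alone, this is the first sign that the series can give a number at all on this read-out: compound 4 gives 18000 nM, so a methyl at this carbon is not needed for a number to appear, although the step as printed does not establish a change beyond the scatter. The other compounds still offer no number to set against compound 4, and their order remains unreadable: the limit of > 25000 nM in this assay, at which 3 of the 4 values shown sit.

Going by these compounds, how far compound 4 truly lies from compound 1 stays open, as does whether the chloro group of compound 4 is needed for its number. Also open, on these data alone, is how an amine, a methoxy group or an ethyl chain on this same carbon would read in this assay, and so whether the result reflects something particular to hydrogen or holds for other replacements of the methyl.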